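Moving the Methyl Group on the Phenoxy Ring

This account rests on a few compounds, and the source may have more. Where it says the series, first, only, none or still open, it means among the compounds named here.

Measured compounds:
compound 1, `CCCCc1ccc(NS(=O)(=O)c2ccc(F)cc2)cc1`, 68%
compound 2, `O=S1(=O)c2ccccc2CN1c1cccc(Oc2ccccc2)c1`, 39%
compound 3, `Cc1ccccc1Oc1cc(F)cc(N2Cc3ccccc3S2(=O)=O)c1`, 71%

In a functional assay on Flp-In T-REx293 cells for antagonist activity at Free fatty acid receptor 1 (Homo sapiens), read by calcium flux (a higher number here means a larger maximal response, a lower number a smaller maximal response), compound 3 gives the highest number of the three, though compound 1 sits within the usual scatter of it, while compound 2 lies clearly lower. Compound 4, `Cc1ccc(Oc2cc(F)cc(N3Cc4ccccc4S3(=O)=O)c2)cc1`, is not yet measured. It differs from compound 3 in one place: 4-methylphenyl in place of 2-methylphenyl on an oxygen on an aromatic ring. The same atoms are present, joined differently. Going by the values given here, no measured pair shows what moving the methyl group does here, so nothing in these numbers points in either direction. Compound 4 is therefore expected to stay near compound 3, with a step from compound 3 to compound 4 of a number 6 percentage points lower from compound 3 to compound 4 (within the scatter) that is estimated to be within the scatter. Compound 4 is expected to give 65%, ranging from 45% to 85%.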

Compound 4, largest response reached (reported as Imax), in percent of the reference or control that the assay uses: 52%
For compound 4 the middle estimate is 13 percentage points above the measured one; low and high end bracket the measured number.
By their numbers in this assay, from the lowest: compound 2; then compound 4; then compounds 1 and 3 (each within the scatter of the next).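

In this assay, putting 4-methylphenyl in place of 2-methylphenyl on the oxygen gives a number 19 percentage points lower from compound 3 to compound 4 (beyond the scatter), with no atom added or removed. Going by these compounds alone, the placement of the methyl group on this ring therefore changes the maximal response, something no earlier pair could show, as none differed in only one place. Nothing available explains why the response falls. On these data alone, it remains open how a methoxy group or a chlorine in place of the methyl group would read out here. Whether an ethyl group would keep the higher or the lower response is also unanswered.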